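A Bromine Added to the Fused Ring of Compound 3

This account rests on a few compounds, and the source may have more. Where it says the series, first, only, none or still open, it means among the compounds named here.

Compound 1 `O=c1oc2ccccc2cc1-c1cn2nc(-c3c([O-])[o+]nn3-c3ccccc3)sc2n1`: 6.3 ug/mL
Compound 2 `O=c1oc2ccccc2cc1-c1cn2nc(-c3c([O-])[o+]nn3-c3ccc(Cl)cc3)sc2n1`: 4 ug/mL
Compound 3 `COc1ccc(-n2n[o+]c([O-])c2-c2nn3cc(-c4cc5ccccc5oc4=O)nc3s2)cc1`: 3.14 ug/mL

In a functional assay on HT-29 cells (Homo sapiens) for cytotoxicity, read by sulforhodamine B assay (on this read-out higher numbers stand for weaker inhibition of growth and lower numbers for stronger inhibition of growth), compound 3 shows the lowest of the three numbers, but the steps of a 2.0-fold lower number from compound 1 to compound 3 (0.30 log units; within the scatter) and a 1.3-fold lower number from compound 2 to compound 3 (0.11 log units; within the scatter) both stay within the scatter, as does a 1.6-fold lower number from compound 1 to compound 2 (0.20 log units; within the scatter); the three compounds are indistinguishable on this read-out. Compound 4 `COc1ccc(-n2n[o+]c([O-])c2-c2nn3cc(-c4cc5cc(Br)ccc5oc4=O)nc3s2)cc1` differs from compound 3 by bromo in place of hydrogen on an aromatic carbon. Among the measured compounds shown here, none of the measured steps touches this fused ring; all three vary the substituent on the other phenyl ring and stay within the scatter. For the measured compounds named here, the only halogen step, a 1.6-fold lower number from compound 1 to compound 2 (0.20 log units; within the scatter), was small. Compound 4 is therefore expected to give 2.8 ug/mL, with a range from 1.2 ug/mL to 7 ug/mL, and the expected step of a 1.1-fold lower number from compound 3 to compound 4 (0.05 log units; within the scatter) lies within the scatter.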

Compound 4, concentration for 50% growth inhibition: 3.04 ug/mL
Compound 4: middle estimate off by 1.1-fold (0.04 log units), on the low side; the measured number falls inside the stated range.
By their numbers in this assay, from the lowest: compounds 4, 3, 2 and 1 (each within the scatter of the next, the first and the last beyond it).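

Among the compounds shown here, the bromo in place of hydrogen gives the first reading on the fused ring itself, since all earlier steps lay on the other phenyl ring. In this assay the change amounts to a 1.0-fold lower number from compound 3 to compound 4 (0.01 log units; within the scatter) and so leaves growth inhibition indistinguishable, showing that this aromatic carbon carries a bromine without a step beyond the scatter. No evidence shown here bears on why this should be so.

On these data alone, with only hydrogen and bromo compared at this carbon, it remains open how an amine, a carboxylic acid or a longer chain would read there. As far as these compounds go, the other carbons of this ring also remain open.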